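A Switch From Piperidine to Hydroxyphenylamino on the Amide

The source may hold more compounds than are shown below. What is called first, only, known or untested is meant among the compounds shown, and "the series" means these compounds.

Compound 1 `O=C(c1c(O)ccc2cc(-c3cccc(O)c3)ccc12)N1CCCCC1` carries a piperidin-1-yl group on the carbonyl carbon of its amide. Among the compounds with values here, in an in vitro assay on Sf9 cells for inhibition of 17-beta-hydroxysteroid dehydrogenase type 1 (Homo sapiens), tested at 1 uM (a lower number here means a weaker effect, a higher number a stronger effect of the compound at the concentration tested), compound 1 gives 73%, the higher of the two values measured so far. Compound 2 `O=C(Nc1ccccc1)c1cc2cc(-c3cccc(O)c3)ccc2cc1O`, whose amide carries an anilino group, gives 62% in this assay; the gap between these two numbers lies beyond the usual scatter.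

Compound 3 `O=C(Nc1cccc(O)c1)c1c(O)ccc2cc(-c3cccc(O)c3)ccc12` has not yet been measured. It differs from compound 1 in one place: (3-hydroxyphenyl)amino in place of piperidin-1-yl on a carbonyl carbon. Within the data shown here, since the two measured compounds differ in more than this one place, no measured step shows what this exchange alone does. The value of compound 2 suggests that an aromatic amine on the carbonyl can sit somewhat below the piperidine. A modest downward step is therefore expected, a number 8 percentage points lower from compound 1 to compound 3 (within the scatter), though one that may still fall within the scatter. Compound 3 is estimated to reach 65% in this assay, within a range from 45% to 85%.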

Compound 3, a percentage reported as inhibition, at one concentration (the size of the read-out at that concentration, not a potency): 70%
The estimate for compound 3 lay 5 percentage points below the measured number, and the stated range covers the measured number.
By their numbers in this assay, from the lowest: compounds 2, 3 and 1 (each within the scatter of the next, the first and the last beyond it).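

In this assay, within the data shown here, the exchange of piperidin-1-yl for (3-hydroxyphenyl)amino on a carbonyl carbon is the first change in a single place that can be read, and it gives a number 3 percentage points lower from compound 1 to compound 3 (within the scatter). On the core of compound 1, this position can therefore carry either a six-membered non-aromatic ring or a six-membered aromatic ring joined through the amide hydrogen's nitrogen, and the two compounds cannot be told apart in this read-out. No measurement shown gives a reason for this result.

The compounds shown leave open whether the hydroxyl on the new phenyl ring contributes anything, since no unsubstituted anilino group stands on this same core. They also leave open how a morpholin-4-yl ring or an open-chain diethylamino group would read at this position.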